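A few compounds are considered here, and "the series" means these few. Any claim that something is new, unique, unknown or untested is made for them only; others in the source may bear on it.

Measured so far:
Compound 1 `FC(F)(F)c1cccc(-c2nc3cnc(Nc4ccccn4)cc3[nH]2)c1` in a physicochemical assay for solubility, using the shake flask method, in phosphate buffer, measured as kinetic solubility, with a stated time of 20 h, at pH 6.5 (on this read-out higher numbers stand for higher solubility and lower numbers for lower solubility), gives < 5000 nM, which is a limit of the assay and not a number.
Compound 2 `COc1ccnc(Nc2cc3[nH]c(-c4cccc(C(F)(F)F)c4)nc3cn2)c1` in this assay gives < 5000 nM, again a limit rather than a number.
Compound 3 `O=C(O)c1ccnc(Nc2cc3[nH]c(-c4cccc(C(F)(F)F)c4)nc3cn2)c1` in this assay gives < 5000 nM, also a limit and not a number.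

Compound 3 therefore stands only at a limit, and so do the two others; all three values sit at the same limit (the limit of < 5000 nM in this assay, at which 3 of the 3 values shown sit). The piece follows the step from compound 3 to compound 4 `FC(F)(F)c1cccc(-c2nc3cnc(Nc4cc(-c5nnn[nH]5)ccn4)cc3[nH]2)c1`, where the change is 1H-tetrazol-5-yl in place of carboxy on an aromatic carbon. The measured steps that touch this position are a step that the two limits leave unreadable from compound 1 to compound 3 and a step that the two limits leave unreadable from compound 2 to compound 3, and the step that the two limits leave unreadable from compound 1 to compound 2 is no more readable. None of them gives a size or a direction, so nothing measured says how far the new group can move the value, or whether it moves it at all beyond the scatter. The step expected from compound 3 to compound 4 in this assay is a step that the limit leaves unreadable from compound 3 to compound 4, with the number most likely again at a limit. For compound 4 the expected solubility is 3000 nM, within a range from 500 nM to 15000 nM.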

Compound 4, solubility: < 5000 nM
Compound 4: only a limit was reported; the forecaster's own chance of this, stated with the estimate: 60%; the middle value does not contradict the limit.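

In this assay compound 4 gives < 5000 nM, which is a limit and not a number. No step from compound 1, compound 2 or compound 3 to compound 4 can be read: the limit of < 5000 nM in this assay, at which 4 of the 4 values shown sit.

The compounds shown leave open whether changing this one group alters solubility at all, and in which direction.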